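Working notes: the step from compound 3 to compound 4

The source may report more compounds than this note shows. Statements on the series, on what has been measured and on what is new or still open speak of the compounds shown alone.

Measured so far in a functional assay, read by spectrophotometry, with a stated time of 30 min; on this read-out higher numbers stand for weaker inhibition and lower numbers for stronger inhibition:
- compound 1 `O=C(/C=C/c1ccccc1)NCCC1CCN(Cc2ccccc2)CC1` gives > 200000 nM as a limit of the assay, not a number
- compound 2 `CC(C)(C)c1cc(CCC(=O)NCC2CCN(Cc3ccccc3)CC2)cc(C(C)(C)C)c1O` gives 63400 nM as a number
- compound 3 `Cc1ccccc1CN1CCC(CCNC(=O)/C=C/c2cc(C(C)(C)C)c(O)c(C(C)(C)C)c2)CC1` gives 65300 nM as a number

For the measured compounds named here, compound 3 stands within the scatter of compound 2, and these are the only two true numbers in the set. Compound 1 remains a limit.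

The next compound is compound 4 `CC(C)(C)c1cc(/C=C/C(=O)NCCC2CCN(Cc3cccc(Cl)c3)CC2)cc(C(C)(C)C)c1O` and the change is 3-chlorophenyl in place of 2-methylphenyl on a saturated chain carbon bound to an amine nitrogen in a ring with 3-chlorophenyl in place of 2-methylphenyl on a saturated chain carbon bound to an amine nitrogen in a ring. Going by the values given here, no measured pair in the set isolates this change, so the expectation starts from compound 3 at 65300 nM and stays close to it. The estimated 1.5-fold lower number from compound 3 to compound 4 (0.16 log units; within the scatter) is expected to stay within the scatter in this assay with only a slight lean toward a lower number. Compound 4 is estimated at 45000 nM with 12000 nM to 130000 nM as the expected range.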

Compound 4, half-maximal inhibitory concentration: 83100 nM
Compound 4: the middle estimate sits 1.8-fold (0.27 log units) below what was measured; measured number inside the range.
By their numbers in this assay, from the lowest: compounds 2, 3 and 4 (each within the scatter of the next). At a limit, above all of these: compound 1.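

At this position, on a saturated chain carbon bound to an amine nitrogen in a ring, the exchange of 2-methylphenyl for 3-chlorophenyl gives a 1.3-fold higher number from compound 3 to compound 4 (0.10 log units; within the scatter) in this assay. For the compounds shown here, this is the first step that isolates a single place, and it shows that these two groups, with 7 heavy atoms each, cannot be told apart on this read-out. The data offer no measured property that would account for this step.

The step exchanges the substituent and its place on the ring together, so the contribution of each remains unresolved. Also open, going by these compounds, is whether a benzyl ring carrying a methoxy group or an amine would shift the number beyond the scatter.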